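A few compounds are considered here, and "the series" means these few. Any claim that something is new, unique, unknown or untested is made for them only; others in the source may bear on it.

Compound 1 `CCC(=O)N1CC2CC(C1)N2`: in an assay on SH-EP1 cells for agonist activity at Neuronal acetylcholine receptor; alpha4/beta2 (Homo sapiens), read by FLIPR and calcium flux (on this read-out higher numbers stand for larger maximal responses and lower numbers for smaller maximal responses), compound 1 gives 98%.
Compound 2 `O=C([C@H]1C[C@H]1F)N1CC2CC(C1)N2`: compound 2 gives 110%.

Among these two values compound 2 stands highest, the single measured step being a number 12 percentage points higher from compound 1 to compound 2 (beyond the scatter). Compound 3 `O=C([C@H]1C[C@@H]1F)N1CC2CC(C1)N2` differs from compound 2 only in this: the two compounds have the same atoms and bonds; at least one stereo element is drawn with a configuration in one of them and without one in the other: 1 of 4 stereo elements differ; a stereocentre at a saturated ring carbon is drawn R in compound 2 and S in compound 3. Going by the values given here, no measured step bears directly on such a change of configuration; the one step known, a number 12 percentage points higher from compound 1 to compound 2 (beyond the scatter), concerns a different change and offers little guidance here. A step within the usual scatter is therefore expected, meaning a number 5 percentage points lower from compound 2 to compound 3 (within the scatter). Compound 3 is estimated to give 105%, with a range from 85% to 125%.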

Compound 3, largest response reached (Emax), in percent of the reference or control that the assay uses: 100%
Compound 3: the middle estimate sits 5 percentage points above what was measured, within the range that was stated.
By their numbers in this assay, from the lowest: compounds 1, 3 and 2 (each within the scatter of the next, the first and the last beyond it).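

In this assay, inverting the stereocentre at the saturated ring carbon gives a number 10 percentage points lower from compound 2 to compound 3 (within the scatter), so this read-out does not clearly separate the two configurations. With the S configuration, placing 2-fluorocyclopropyl in place of ethyl gives a number 2 percentage points higher from compound 1 to compound 3 (within the scatter), so the earlier step beyond the scatter does not carry over to this stereoisomer. One point limits how firmly the configurations can be compared: the fact that one of compounds 2 and 3 is drawn with a defined configuration and the other without, at the place where they differ

Going by these compounds, how a plain cyclopropyl without fluorine, or a longer chain such as butyl, would behave on the carbonyl carbon remains open.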